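A few compounds are considered here, and "the series" means these few. Any claim that something is new, unique, unknown or untested is made for them only; others in the source may bear on it.

Measured compounds: compound 1 `Cc1ccc2c(O)cc(-c3cccc(Cl)c3)nc2n1`, compound 2 `Oc1cc(-c2ccc3ccccc3c2)nc2ncccc12`, compound 3 `Cc1cc(C)c2c(O)cc(-c3cccc(Cl)c3)nc2n1`.

In a functional assay on HCT-116 cells (Homo sapiens) for antiproliferative activity (on this read-out higher numbers stand for weaker inhibition of growth and lower numbers for stronger inhibition of growth), compound 1 gives 25.7 nM. Compound 3 in this assay gives 170 nM; the change is methyl in place of hydrogen on an aromatic carbon, and the step is a 6.6-fold higher number from compound 1 to compound 3 (0.82 log units; beyond the scatter). Compound 2 in this assay gives 3800 nM, the highest of the three. How the core of compound 2 differs from the core of compound 1 is not broken down here.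

Compound 4 `Cc1ccnc2nc(-c3ccc4ccccc4c3)cc(O)c12` is not yet measured. Its change from compound 2 is methyl in place of hydrogen on an aromatic carbon. This is the same kind of change as from compound 1 to compound 3, not the same: the earlier place is also meta to a methyl group (1 heavy atom), which the place in compound 2 is not. Since the measured step is a 6.6-fold higher number from compound 1 to compound 3 (0.82 log units; beyond the scatter), a similar, modest weakening is expected, with wider uncertainty as the core differs: a 3.9-fold higher number from compound 2 to compound 4 (0.60 log units; beyond the scatter). Compound 4 is estimated at 15000 nM in this assay, between 4000 nM and 50000 nM.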

Compound 4, concentration for 50% growth inhibition: 427 nM
The estimate for compound 4 lay 35-fold (1.55 log units) above the measured number, and the stated range ends above it.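

In this assay, methyl in place of hydrogen on an aromatic carbon gives an 8.9-fold lower number from compound 2 to compound 4 (0.95 log units; beyond the scatter), so on the core of compound 2 this change strengthens inhibition of growth. The change does not carry over between the two cores, and its direction reverses: the same change on two cores in this assay, a 6.6-fold higher number (0.82 log units; beyond the scatter) from compound 1 to compound 3 and an 8.9-fold lower number (0.95 log units; beyond the scatter) from compound 2 to compound 4, 59-fold (1.77 log units) apart, beyond the scatter of two such steps

Which difference between the cores sets the direction is not shown, and one step on each core gives no rule for the series. Open, from the compounds shown here alone, is how other groups on that aromatic carbon, such as ethyl, methoxy or an amine, behave on either core. Equally open, going by these compounds, is whether either direction holds on any further core.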